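One More Inverted Stereocentre and Its Expected Cytotoxicity

The source may hold more compounds than are shown below. What is called first, only, known or untested is meant among the compounds shown, and "the series" means these compounds.

In a functional assay on CCRF-CEM cells (Homo sapiens) for cytotoxicity (on this read-out higher numbers stand for weaker inhibition and lower numbers for stronger inhibition), compound 1 `C=C1C(=O)O[C@H]2C[C@@H](C)C3=C(C[C@H]12)[C@@]1(C)C[C@@H]3C[C@@]12C(=O)O[C@@H]1C[C@@]3(C)[C@@H](O)C[C@@H](O)C(=C)[C@@H]3C[C@@H]12` gives 140 nM and compound 2 `C=C1C(=O)O[C@H]2C[C@H](C)C3=C(C[C@H]12)[C@@]1(C)C[C@@H]3C[C@@]12C(=O)O[C@@H]1C[C@@]3(C)[C@@H](O)C[C@@H](O)C(=C)[C@@H]3C[C@@H]12` gives 140 nM, so compound 2 stands level with compound 1. Going by the values given here, the only measured step shows no change at the digits printed from compound 1 to compound 2 (within the scatter), and it concerns (the fact that compounds 1 and 2 differ only in the configuration as drawn). Compound 3 `C=C1C(=O)O[C@H]2C[C@H](C)C3=C(C[C@H]12)[C@@]1(C)C[C@H]3C[C@@]12C(=O)O[C@@H]1C[C@@]3(C)[C@@H](O)C[C@@H](O)C(=C)[C@@H]3C[C@@H]12` has not yet been measured. Set against compound 2, it shows (the two compounds have the same atoms and bonds and differ only in configuration as drawn: 1 of 12 stereo elements differ; a stereocentre at a saturated ring carbon is drawn R in compound 2 and S in compound 3). This is a second change of configuration, but at a different stereocentre, so the earlier step is only a loose guide. Among the compounds with values here, since the single inversion from compound 1 to compound 2 gave no change at the digits printed from compound 1 to compound 2 (within the scatter), no shift beyond the scatter and no firm direction are expected here, although the range stays wide. The expected size of the change is a 1.1-fold higher number from compound 2 to compound 3 (0.06 log units; within the scatter). For compound 3 the estimated value is 160 nM, with an expected range from 50 nM to 450 nM.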

Compound 3, half-maximal inhibitory concentration: 140 nM
For compound 3 the middle estimate is 1.1-fold (0.06 log units) above the measured one, within the range that was stated.
By their numbers in this assay, from the lowest: compounds 1, 2 and 3 (each within the scatter of the next).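

Inverting a second saturated ring carbon also leaves the read-out in place: in this assay this inversion gives no change at the digits printed from compound 2 to compound 3 (within the scatter). The new information is that this result holds at a different stereocentre, and that the two inversions combined, which the earlier pair could not test, give no change at the digits printed from compound 1 to compound 3 (within the scatter). Nothing else separates the closest pair, so this comparison rests on configuration alone: the fact that compounds 2 and 3 differ only in the configuration as drawn.

The compounds shown speak only to these two stereocentres, so it remains open whether inverting any of the others in the shared core would leave the value equally unmoved. As far as these compounds go, it is also open whether the same indifference to configuration would persist with an amine or a longer chain attached to that core.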